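From a Drawn Stereocentre to an Undrawn One

The source may report more compounds than this note shows. Statements on the series, on what has been measured and on what is new or still open speak of the compounds shown alone.

In a functional assay on the whole organism (strain Swiss CD-1) with Mus musculus as the target, in the maximal electroshock model, with stated times of 2 h and 2 s (on this read-out higher numbers stand for an effect only at larger amounts of compound and lower numbers for an effect already at smaller amounts), compound 1 `COC[C@@H](C(=O)N1CCN(c2ccc(C(F)(F)F)cc2)CC1)N1C(=O)CCC1=O` gives > 120 mg/kg, which is a limit of the assay and not a number. Compound 2 `COC[C@H](C(=O)N1CCN(c2ccc(C(F)(F)F)cc2)CC1)N1C(=O)CCC1=O` gives 80.9 mg/kg, the only number shown, and it differs from compound 1 only in configuration (the fact that compounds 1 and 2 differ only in the configuration as drawn). Within the data shown here, the one measured step bearing on what follows is an at least 1.4-fold lower number from compound 1 to compound 2 (0.17 log units; that floor lies within the scatter). Compound 3 `COCC(C(=O)N1CCN(c2ccc(C(F)(F)F)cc2)CC1)N1C(=O)CCC1=O` then brings this change: the two compounds have the same atoms and bonds; at least one stereo element is drawn with a configuration in one of them and without one in the other: 1 of 1 stereo elements differ; a stereocentre at a saturated chain carbon is drawn R in compound 2 and without a configuration in compound 3. With that step so small, no shift beyond the scatter is expected in this assay. The expected change is a 1.3-fold higher number from compound 2 to compound 3 (0.11 log units; within the scatter), toward a slightly higher number. Compound 3 is estimated at 105 mg/kg, with a range of 65 mg/kg to 170 mg/kg.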

Compound 3, dose for half-maximal effect: 79.5 mg/kg
Compound 3: the middle estimate sits 1.3-fold (0.12 log units) above what was measured; the measured number falls inside the stated range.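

In this assay, removing the drawn configuration at the saturated chain carbon gives a 1.0-fold lower number from compound 2 to compound 3 (0.01 log units; within the scatter), so the two cannot be told apart at this position. Compound 1 gives > 120 mg/kg, which is a limit of the assay and not a number. From the compounds shown here alone, its comparison with the undrawn form reads an at least 1.5-fold lower number from compound 1 to compound 3 (0.17 log units; that floor lies within the scatter), and this is only a floor, so the true size of that gap remains unknown.

Going by these compounds, whether a longer chain or an amine at this position would move the number beyond the scatter stays open.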